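From an Iodophenyl to a Nitrophenyl Substituent

This account rests on a few compounds, and the source may have more. Where it says the series, first, only, none or still open, it means among the compounds named here.

Compound 1 `COc1ccc(/C=C\C(=O)O)c(OCc2cn(-c3ccccc3F)nn2)c1CC=C(C)C`: 14500 nM
Compound 2 `COc1ccc(/C=C\C(=O)O)c(OCc2cn(-c3ccccc3)nn2)c1CC=C(C)C`: 32300 nM
Compound 3 `COc1ccc(/C=C\C(=O)O)c(OCc2cn(-c3ccccc3I)nn2)c1CC=C(C)C`: "not determined" (no result reported)

In a functional assay on COLO 205 cells (Homo sapiens) for cytotoxicity, read by MTT assay, with a stated time of 24 h (on this read-out lower numbers stand for stronger inhibition and higher numbers for weaker inhibition), compound 1 gives 14500 nM and compound 2 gives 32300 nM; the step of a 2.2-fold higher number from compound 1 to compound 2 (0.35 log units; beyond the scatter) is the only measured one. Compound 3 `COc1ccc(/C=C\C(=O)O)c(OCc2cn(-c3ccccc3I)nn2)c1CC=C(C)C` has no number in this assay, so it stands nowhere on the measured scale. Compound 4 `COc1ccc(/C=C\C(=O)O)c(OCc2cn(-c3cccc([N+](=O)[O-])c3)nn2)c1CC=C(C)C` differs from it by 3-nitrophenyl in place of 2-iodophenyl on an aromatic nitrogen. Among the measured compounds shown here, the one measured step concerns fluoro against hydrogen on the same phenyl group and does not cover this change, so no direction can be read from it beyond the narrow span the two measured values occupy. Compound 4 is therefore expected near those values, at an estimated 20000 nM with a range from 7000 nM to 60000 nM.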

Compound 4, half-maximal inhibitory concentration: 6900 nM
Estimate against measurement, compound 4: 2.9-fold (0.46 log units) above; the whole stated range lies above it.
By their numbers in this assay, from the lowest: compound 4; then compound 1; then compound 2.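

In this assay, nitro in place of hydrogen on the phenyl group gives a 4.7-fold lower number from compound 2 to compound 4 (0.67 log units; beyond the scatter), and 3-nitrophenyl in place of 2-fluorophenyl gives a 2.1-fold lower number from compound 1 to compound 4 (0.32 log units; beyond the scatter), so compound 4 has the lowest number of the three measured compounds. Compound 3 has no number, so the step from it to compound 4 cannot be read. Nothing available explains these differences. As far as these compounds go, whether the lower number follows the nitro group itself or its place on the phenyl group remains open. From the compounds shown here alone, it is also open how an amine or a carboxylic acid would fare on this phenyl group.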